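The compounds below may be only part of what the source reports. "The series", "measured", "known", "first", "only" and "open" are said of these compounds alone.

Measured compounds:
compound 1 `CC(C)(C)N(NC(=O)c1ccccc1F)C(=O)c1ccccc1Cl` — 51.3 nM
compound 2 `CC(C)(C)N(NC(=O)c1cccc(C#N)c1)C(=O)c1ccccc1Cl` — 955 nM
compound 3 `Cc1ccc(C(=O)NN(C(=O)c2ccccc2Cl)C(C)(C)C)cc1` — 18.6 nM

In an assay on cells for agonist activity at ecdysone receptor (Bombyx mori), read by a luciferase reporter, with a stated time of 24 h (a lower number here means that less compound is needed, a higher number that more compound is needed for the effect), compound 3 stands lowest of the three, set apart by the step of a 2.8-fold lower number from compound 1 to compound 3 (0.44 log units; beyond the scatter) and by the larger step of a 51-fold lower number from compound 2 to compound 3 (1.71 log units; beyond the scatter). Compound 4 `CCCCCCC(=O)NN(C(=O)c1ccccc1Cl)C(C)(C)C` carries hexyl in place of 4-methylphenyl on a carbonyl carbon. Every measured step swaps one aromatic ring for another, as in a 19-fold higher number from compound 1 to compound 2 (1.27 log units; beyond the scatter); none replaces the ring with a chain, so none bears directly on this change. Those steps show only that the part on this carbonyl carbon moves the number strongly. Compound 4 is therefore expected to give a higher number, about 300 nM, with a range from 50 nM to 3000 nM. This estimate means a step of a 16-fold higher number from compound 3 to compound 4 (1.21 log units; beyond the scatter) in this assay, and its direction is uncertain.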

Compound 4, half-maximal effective concentration: 741 nM
Estimate against measurement, compound 4: 2.5-fold (0.39 log units) below; the range from low to high includes it.
By their numbers in this assay, from the lowest: compound 3; then compound 1; then compounds 4 and 2 (each within the scatter of the next).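

In this assay hexyl on this carbonyl carbon fares far worse than two of the aromatic rings, with a 40-fold higher number from compound 3 to compound 4 (1.60 log units; beyond the scatter) and a 14-fold higher number from compound 1 to compound 4 (1.16 log units; beyond the scatter) in the same direction. Yet with a 1.3-fold lower number from compound 2 to compound 4 (0.11 log units; within the scatter) the chain stands level with 3-cyanophenyl, so an aromatic ring here does not by itself bring a low number. Nothing measured here explains these steps. On these data alone, whether a shorter chain, a longer chain or a chain ending in an amine would behave like hexyl remains open. So does whether a saturated ring such as cyclohexyl would come closer to compound 3.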